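From 4-cyanobenzyl to 4-hydroxybenzyl in compound 4

The source may hold more compounds than are shown below. What is called first, only, known or untested is meant among the compounds shown, and "the series" means these compounds.

compound 1 `COc1ccc(CSc2nc(O)c(C)c(Cc3c(Cl)cccc3Cl)n2)cc1OC` gives > 55000 nM
compound 2 `COc1ccc(CSc2nc(O)c(C)c(Cc3c(Cl)cccc3Cl)n2)c(OC)c1` gives > 55000 nM
compound 3 `Cc1c(O)nc(SCc2ccc(C#N)cc2)nc1Cc1c(Cl)cccc1Cl` gives > 60000 nM

All three entries come from a functional assay on MT4 cells (Homo sapiens) for cytotoxicity, read by MTT assay (a higher number here means that more compound is tolerated, a lower number that less compound is tolerated), and each of them is a limit of the assay and not a number. Compound 3 stands at > 60000 nM, which is likewise only a limit. Among the measured compounds shown here, no measured number therefore places compound 3 exactly, and no pair of measured compounds differs in one place.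

Compound 4 `Cc1c(O)nc(SCc2ccc(O)cc2)nc1Cc1c(Cl)cccc1Cl` has not yet been measured. It carries hydroxy in place of cyano on an aromatic carbon, para to a large group (hydroxy in place of cyano on an aromatic carbon).

The data give no measured size for a change of this kind, and the expectation rests on the limits reached by compounds 1, 2 and 3 in this assay. The expected at least 1.3-fold lower number from compound 3 to compound 4 (0.12 log units; that floor lies within the scatter) is none beyond the scatter, with any drift more likely downward. For compound 4 the estimate is 45000 nM, with an expected range of 15000 nM to 90000 nM.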

Compound 4, half-maximal cytotoxic concentration: 41000 nM
Compound 4: middle estimate off by 1.1-fold (0.04 log units), on the high side, and the stated range covers the measured number.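

In this assay compound 4 gives 41000 nM, the first entry in this set that is a number and not a limit of the assay. For hydroxy in place of cyano, on an aromatic carbon para to a large group, the data give an at least 1.4-fold lower number from compound 3 to compound 4 (0.16 log units; that floor lies within the scatter). Only this floor can be read for the change, and not its full size, because compound 3 stands at a limit: the limit of > 60000 nM in this assay, at which 1 of the 4 values shown sits.

The compounds shown leave open how an amine or a carboxylic acid in this same place would read in this assay, and whether either would stay close to compound 4. From the compounds shown here alone, it also stays open whether hydroxy in place of cyano would read alike on a core other than the one shared here.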